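This account rests on a few compounds, and the source may have more. Where it says the series, first, only, none or still open, it means among the compounds named here.

Compound 1 `COc1cc(N(C)CCN(C)C)c(NC(=O)/C=C\C(C)C)cc1Nc1ncc(C#N)c(-c2cn(C)c3ccccc23)n1` gives 1110 nM. Compound 2 `CCC/C=C\C(=O)Nc1cc(Nc2ncc(C#N)c(-c3cn(C)c4ccccc34)n2)c(OC)cc1N(C)CCN(C)C` gives 823 nM. Compound 3 `COc1cc(N(C)CCN(C)C)c(NC(=O)/C=C\C(C)C)cc1Nc1nc(C)cc(-c2cn(C)c3ccccc23)n1` gives 1230 nM.

All three numbers come from a functional assay on NCI-H1975 cells (Homo sapiens) for antiproliferative activity, read by MTT assay, with a stated time of 72 h; on this read-out higher numbers stand for weaker inhibition and lower numbers for stronger inhibition. Compound 4 `CCC/C=C\C(=O)Nc1cc(Nc2nc(C)cc(-c3cn(C)c4ccccc34)n2)c(OC)cc1N(C)CCN(C)C` has not yet been measured in this assay. Compound 1 and compound 2 differ by propyl in place of isopropyl on a double-bonded chain carbon bound to a double-bonded chain carbon, and that change gave a 1.3-fold lower number from compound 1 to compound 2 (0.13 log units; within the scatter). Compound 3 and compound 4 differ by propyl in place of isopropyl on a double-bonded chain carbon bound to a double-bonded chain carbon, the same change at the same place. The cores of compound 1 and compound 3 differ, but that difference is not broken down here; compound 3 and compound 1 give numbers within the scatter of each other. For compound 4 the expected step is a 1.4-fold lower number from compound 3 to compound 4 (0.14 log units; within the scatter), because the same change in the other core gave a 1.3-fold lower number from compound 1 to compound 2 (0.13 log units; within the scatter). Compound 4 is therefore estimated at 900 nM, with a likely range from 450 nM to 1800 nM.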

Compound 4, half-maximal inhibitory concentration: 254 nM
The estimate for compound 4 lay 3.5-fold (0.55 log units) above the measured number, and the stated range ends above it.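

In this assay, propyl in place of isopropyl gives a 4.8-fold lower number from compound 3 to compound 4 (0.69 log units; beyond the scatter), and the size of this step does not carry from one core to the other: the same change on two cores in this assay, a 1.3-fold lower number (0.13 log units; within the scatter) from compound 1 to compound 2 and a 4.8-fold lower number (0.69 log units; beyond the scatter) from compound 3 to compound 4, 3.6-fold (0.56 log units) apart, beyond the scatter of two such steps. Going by these compounds alone, only the step on the core of compound 3 lies beyond the scatter, so a shared gain on both cores cannot be claimed. These two pairs show that the outcome of the change differs with the core, but not which feature of the cores sets that difference or what the change would do on a third core.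

Still open, as far as these compounds go, is whether a longer chain, such as butyl, at the same place on a double-bonded chain carbon bound to a double-bonded chain carbon would extend the step seen on the core of compound 3. Also open, from the compounds shown here alone, is whether the same gap between the cores would appear with that chain.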